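This account rests on a few compounds, and the source may have more. Where it says the series, first, only, none or still open, it means among the compounds named here.

Measured compounds in an ADME assay on BJ cells (Homo sapiens) for cytotoxicity, read by CellTiter-Glo and resazurin assay, with a stated time of 72 h; a higher number here means that more compound is needed for the effect, a lower number that less compound is needed:
- compound 1 `CC(C)N(Cc1cccc(OCCCCCC(=O)O)c1)C(=O)c1ccc(-c2cccc3ccccc23)cc1`; in this assay compound 1 gives < 1.3 nM, which is a limit of the assay.
- compound 2 `CC(=O)c1cccc(-c2ccc(C(=O)N(Cc3cccc(OCCCCCC(=O)O)c3)C(C)C)cc2)c1`; in this assay compound 2 gives > 26000 nM, a limit.
- compound 3 `CC(C)COc1cccc(-c2ccc(C(=O)N(Cc3cccc(OCCCCCC(=O)O)c3)C(C)C)cc2)c1`; in this assay compound 3 gives > 26000 nM, a limit.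

For the measured compounds named here, compound 3 thus stands at the upper limit of this assay, with only that limit and no number known for it; two of the three values shown sit at this limit (the limit of > 26000 nM in this assay, at which 2 of the 3 values shown sit), and the remaining one sits at the lower limit (the limit of < 1.3 nM in this assay, at which 1 of the 3 values shown sits). The two readable steps, an at least 20000-fold higher number from compound 1 to compound 2 (4.30 log units; beyond the scatter) and an at least 20000-fold higher number from compound 1 to compound 3 (4.30 log units; beyond the scatter), are both large and run in the same direction; the step that the two limits leave unreadable from compound 2 to compound 3 cannot be read because both ends are limits.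

Compound 4 `CC(C)N(Cc1cccc(OCCCCCC(=O)O)c1)C(=O)c1ccc(-c2cccc(OCc3ccccc3)c2)cc1` is compound 3 with phenyl in place of isopropyl on a saturated chain carbon bound to an oxygen on an aromatic ring. Going by the values given here, none of the measured steps touches this position: the measured changes all replaced naphthalen-1-yl by a substituted phenyl, and the 3-(isobutoxy)phenyl of compound 3 is kept here apart from the group on its oxygen. With nothing measured in this direction, the expectation for compound 4 is that it stays at the upper limit, a step that the limit leaves unreadable from compound 3 to compound 4 that is expected to stay within the scatter. The estimate for compound 4 is 30000 nM, with a range from 6000 nM to 120000 nM.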

Compound 4, half-maximal effective concentration: > 26000 nM
Compound 4: no number, only a limit; the forecaster's own chance of this, stated with the estimate: 75%; the middle value is on the limit's open side.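

In this assay compound 4 gives > 26000 nM, a limit and not a number. Compound 2 and compound 3 also stand at limits, and the steps linking them to compound 4 cannot be read. The compounds shown leave open how benzyloxy, isobutoxy and acetyl compare in this assay, since none of the three gives a number.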